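Anilino variants of a shared core: ethoxyphenyl step

The source may report more compounds than this note shows. Statements on the series, on what has been measured and on what is new or still open speak of the compounds shown alone.

Compound 1 `Cc1ccc(NC2=CC(=O)c3nc4n(c3C2=O)[C@H]2OC[C@@H](O)[C@H]2OC4)cc1` gives 1420 nM in a functional assay on MGC-803 cells (Homo sapiens) for inhibition, read by sulforhodamine B assay; a lower number here means a stronger inhibitor, a higher number a weaker inhibitor.
Compound 2 `O=C1C(NC2CC2)=CC(=O)c2c1nc1n2[C@H]2OC[C@@H](O)[C@H]2OC1` gives only a limit in this assay, > 4000 nM.
Compound 3 `CCc1ccc(NC2=CC(=O)c3nc4n(c3C2=O)[C@H]2OC[C@@H](O)[C@H]2OC4)cc1` gives 1290 nM in this assay.

Compound 3 holds the lowest of the two numbers shown, with compound 1 nearest: a 1.1-fold lower number from compound 1 to compound 3 (0.04 log units; within the scatter), so the two cannot be told apart. The value of compound 2 is a limit, not a number (the limit of > 4000 nM in this assay, at which 1 of the 3 values shown sits).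

Compound 4 `CCOc1ccccc1NC1=CC(=O)c2nc3n(c2C1=O)[C@H]1OC[C@@H](O)[C@H]1OC3` differs from compound 3 by 2-ethoxyphenyl in place of 4-ethylphenyl on an amine nitrogen. Going by the values given here, the only measured step, a 1.1-fold lower number from compound 1 to compound 3 (0.04 log units; within the scatter), concerns methyl in place of hydrogen on a saturated chain carbon bound to an aromatic carbon and stays within the scatter. Among the compounds with values here, no measured step covers 2-ethoxyphenyl in place of 4-ethylphenyl on the amine nitrogen, so the series gives no direction for it. The step of a 1.2-fold higher number from compound 3 to compound 4 (0.09 log units; within the scatter) is therefore expected to be small, with a wide band around it. Compound 4 is expected at 1600 nM, between 600 nM and 4000 nM.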

Compound 4, half-maximal inhibitory concentration: 2450 nM
For compound 4 the middle estimate is 1.5-fold (0.19 log units) below the measured one; measured number inside the range.
By their numbers in this assay, from the lowest: compounds 3, 1 and 4 (each within the scatter of the next). At a limit, above all of these: compound 2.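

In this assay, 2-ethoxyphenyl in place of 4-ethylphenyl on the amine nitrogen, which adds an oxygen and a hydrogen-bond acceptor to the group, gives a 1.9-fold higher number from compound 3 to compound 4 (0.28 log units; within the scatter), and the matching change from 4-methylphenyl gives a 1.7-fold higher number from compound 1 to compound 4 (0.24 log units; within the scatter). Both steps stay within the scatter, so an aryl group with a quite different substituent on this nitrogen still cannot be told apart from the two alkyl-substituted phenyl groups, which the step between compound 1 and compound 3 alone could not show. Nothing measured here accounts for these steps.

On these data alone, it remains open whether any aryl group at this position can move the number beyond the scatter. A phenyl group carrying a carboxylic acid or an amine, or a longer chain in place of ethoxy, would test this.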